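The source may report more compounds than this note shows. Statements on the series, on what has been measured and on what is new or still open speak of the compounds shown alone.

Working notes on the step out of compound 3. In an in vitro ADME assay on microsomes from liver (Mus musculus) for pharmacokinetics, read by LC-MS, with a stated time of 10 min, tested at 1 uM (a lower number here means slower removal, a higher number faster removal of the compound), compound 3 (`COc1cccc(NC(=O)[C@H]2CN(C)C[C@@H]2c2ccc(/C=C/C(=O)Nc3ccccc3N)cc2)c1`) gives 65 mL/min/kg. Compound 1 (`CC(C)c1ccc(NC(=O)[C@H]2CN(C)C[C@@H]2c2ccc(/C=C/C(=O)Nc3ccccc3N)cc2)cc1`) gives 54 mL/min/kg, and the comparison of the two, a 1.2-fold higher number from compound 1 to compound 3 (0.08 log units; within the scatter), places them together. Among the compounds with values here, compound 2 (`CN1C[C@H](C(=O)Nc2ccc(Br)cc2)[C@@H](c2ccc(/C=C/C(=O)Nc3ccccc3N)cc2)C1`) gives 16 mL/min/kg, the one number of the three that stands clearly apart.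

Compound 4 (`CN1C[C@H](C(=O)Nc2ccc(F)c(Br)c2)[C@@H](c2ccc(/C=C/C(=O)Nc3ccccc3N)cc2)C1`) changes the group on the amide-type nitrogen: 3-bromo-4-fluorophenyl in place of 3-methoxyphenyl on an amide-type nitrogen. In words, 3-bromo-4-fluorophenyl takes the place of 3-methoxyphenyl.

Within the data shown here, compound 2 is the nearest measured comparison, as its 4-bromophenyl group is the only other bromophenyl group in the set. The step of a 4.1-fold higher number from compound 2 to compound 3 (0.61 log units; beyond the scatter) therefore bears most directly on this change when read in reverse. The step of a 3.4-fold lower number from compound 1 to compound 2 (0.53 log units; beyond the scatter) points the same way, although only compound 2 supports this reading. Among the measured compounds shown here, no measured compound carries the fluoro group or shows what the 3-bromo-4-fluorophenyl pattern does, so the size of the change remains uncertain. A modest move to a lower number is expected in this assay, close to the size of the step from compound 2, with the estimated change being a 3.0-fold lower number from compound 3 to compound 4 (0.47 log units; beyond the scatter). For compound 4 the estimated clearance is 22 mL/min/kg, with an expected range of 10 mL/min/kg to 45 mL/min/kg.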

Compound 4, clearance: 43 mL/min/kg
Beside the measured number, compound 4's estimate is 2.0-fold (0.29 log units) below it; measured number inside the range.
By their numbers in this assay, from the lowest: compound 2; then compounds 4, 1 and 3 (each within the scatter of the next).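

In this assay, the 3-bromo-4-fluorophenyl group on the amide-type nitrogen cannot be told apart from the two groups without bromine, with a 1.5-fold lower number from compound 3 to compound 4 (0.18 log units; within the scatter) and a 1.3-fold lower number from compound 1 to compound 4 (0.10 log units; within the scatter), while a 2.7-fold higher number from compound 2 to compound 4 (0.43 log units; beyond the scatter) separates it from the 4-bromophenyl group. Within the data shown here, compound 2 was the only bromine-bearing compound before this result, so the earlier set could not show whether a bromo substituent on this phenyl ring was enough to give the low number; compound 4 goes against that reading, and among the four compounds only the 4-bromophenyl group of compound 2 stands apart. No measurement shown here bears on what lies behind these numbers.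

The compounds shown leave open whether the fluoro group or the place of the bromo group separates compound 4 from compound 2, as the two groups differ in both at once. Also open, from the compounds shown here alone, is how a 3-bromophenyl group, a 4-chlorophenyl group, or a phenyl ring carrying an amine or a carboxylic acid on this amide-type nitrogen would read in this assay.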